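Swapping the sulfonamide substituent on a pyrazolopyridine ketone

The compounds below may be only part of what the source reports. "The series", "measured", "known", "first", "only" and "open" are said of these compounds alone.

Compound 1, `CCCS(=O)(=O)Nc1ccc(F)c(C(=O)c2n[nH]c3ncc(-c4ccc(S(=O)(=O)NCC)cc4)cc23)c1F`, was tested in an assay for binding affinity to dual specificity mitogen-activated protein kinase kinase 4 (Homo sapiens), read by KINOMEscan, tested at 10 nM (a higher number here means a weaker effect of the compound at the concentration tested, a lower number a stronger effect), and compound 1 gives 41%, the highest of the two numbers recorded. Compound 2, `CCCS(=O)(=O)Nc1ccc(F)c(C(=O)c2n[nH]c3ncc(-c4ccc(S(=O)(=O)NC(C)=O)cc4)cc23)c1F`, differs from it only by an acetyl in place of an ethyl on the sulfonamide nitrogen, and compound 2 gives 0.5%; the step of a number 40.5 percentage points lower from compound 1 to compound 2 (beyond the scatter) is large and beyond the scatter. Compound 3, `CCCS(=O)(=O)Nc1ccc(F)c(C(=O)c2n[nH]c3ncc(-c4ccc(S(N)(=O)=O)cc4F)cc23)c1F`, carries the change (2-fluoro-4-sulfamoylphenyl in place of 4-(ethylsulfamoyl)phenyl on an aromatic carbon). Among the measured compounds shown here, only the step from compound 1 to compound 2 bears on this, and it touches the same sulfonamide nitrogen, which argues that this part of the molecule moves the read-out strongly. Because a number 40.5 percentage points lower from compound 1 to compound 2 (beyond the scatter) is so large, compound 3 is expected to shift in the same direction, though the added fluorine is without precedent here, so the expected step of a number 21 percentage points lower from compound 1 to compound 3 (beyond the scatter) is given with wide uncertainty. Compound 3 is estimated at 20%, in a range from 1% to 60%.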

Compound 3, a percentage reported as activity, at one concentration (the size of the read-out at that concentration, not a potency): 9.4%
Compound 3: middle estimate off by 10.6 percentage points, on the high side; the range from low to high includes it.
By their numbers in this assay, from the lowest: compounds 2 and 3 (each within the scatter of the next); then compound 1.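

In this assay the exchange of 4-(ethylsulfamoyl)phenyl for 2-fluoro-4-sulfamoylphenyl gives a number 31.6 percentage points lower from compound 1 to compound 3 (beyond the scatter), so the acetyl of compound 2 is not the only replacement for the ethyl that goes with a stronger effect at this position. Compound 3, which has no substituent on the sulfonamide nitrogen, gives 9.4% and compound 2 gives 0.5%, two values within the scatter of each other, and so far the ethyl of compound 1 stands alone at the weaker end. No measurement offered here accounts for these differences.

From the compounds shown here alone, the step combines loss of the ethyl with gain of the fluorine, so the share of each remains unknown, and a plain 4-sulfamoylphenyl would be needed to separate them. Going by these compounds, how a methyl, a propyl or a propanoyl on that sulfonamide nitrogen would read also stays open.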